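The source may hold more compounds than are shown below. What is called first, only, known or untested is meant among the compounds shown, and "the series" means these compounds.

Measured in a toxicity assay on HepG2 cells (Homo sapiens) for cytotoxicity, read by MTT assay, with a stated time of 48 h; a higher number here means that more compound is tolerated, a lower number that less compound is tolerated:
Compound 1 `CN1CCCN(S(=O)(=O)c2ccc(-c3ccc4c(Nc5ccc(OCc6cccc(F)c6)c(Cl)c5)nncc4c3)cc2)CC1`: 3.4 uM
Compound 2 `CN1CCN(S(=O)(=O)c2ccc(-c3ccc4cnnc(Nc5ccc(OCc6cccc(F)c6)c(Cl)c5)c4c3)cc2)CC1`: > 5 uM (a limit)

Compound 2 has no exact number in this assay: its > 5 uM is a limit of the assay, so it stands only at that limit. Compound 3 `CN1CCCN(S(=O)(=O)c2ccc(-c3ccc4cnnc(Nc5ccc(OCc6cccc(F)c6)c(Cl)c5)c4c3)cc2)CC1` keeps the core of compound 2 and changes one group: 4-methyl-1,4-diazepan-1-yl in place of 4-methylpiperazin-1-yl on a sulfonyl sulfur. In words, this is 4-methyl-1,4-diazepan-1-yl in place of 4-methylpiperazin-1-yl on a sulfonyl sulfur. Within the data shown here, no measured pair shows this change alone, so its size cannot be read directly. A step no larger than the scatter is expected, if anything towards less compound tolerated, since compound 1, which also carries 4-methyl-1,4-diazepan-1-yl, gives 3.4 uM. The expected move is an at least 1.1-fold lower number from compound 2 to compound 3 (0.04 log units; that floor lies within the scatter). For compound 3 the estimated value is 4.5 uM, with an expected range of 2.5 uM to 9 uM.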

Compound 3, half-maximal toxic concentration: 14 uM
For compound 3 the middle estimate is 3.1-fold (0.49 log units) below the measured one, and the stated range ends below it.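

In this assay no step can be read from compound 2 to compound 3, because compound 2 stands only at a limit: the limit of > 5 uM in this assay, at which 1 of the 3 values shown sits. The compounds shown leave open the size and direction of the change from 4-methylpiperazin-1-yl to 4-methyl-1,4-diazepan-1-yl on a sulfonyl sulfur.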